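Aromatic methyl for fluoro on the fused ring: compound 4

A few compounds are considered here, and "the series" means these few. Any claim that something is new, unique, unknown or untested is made for them only; others in the source may bear on it.

Measured so far in a functional assay on PC-3 cells (Homo sapiens) for inhibition, read by sulforhodamine B assay, with a stated time of 48 h; a higher number here means a weaker inhibitor, a lower number a stronger inhibitor:
compound 1, `COC(=O)[C@@]1(C)C[C@@H](c2coc3ccc(Br)cc3c2=O)N(c2ccccc2)O1`, gives > 60000 nM, a limit of the assay
compound 2, `CCO[C@H]1C[C@@H](c2coc3ccc(F)cc3c2=O)N(c2ccccc2)O1`, gives 31700 nM
compound 3, `O=c1c([C@@H]2C[C@H](c3ccccc3)ON2c2ccccc2)coc2ccc(F)cc12`, gives 49000 nM

Compound 3 holds the highest of the two numbers in this assay; nearest is compound 2, and the step of a 1.5-fold higher number from compound 2 to compound 3 (0.19 log units; within the scatter) stays within the scatter. Compound 1 sits at a limit, (the limit of > 60000 nM in this assay, at which 1 of the 3 values shown sits).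

Compound 4, `Cc1ccc2occ([C@@H]3C[C@H](c4ccccc4)ON3c3ccccc3)c(=O)c2c1`, differs from compound 3 by methyl in place of fluoro on an aromatic carbon. Among the compounds with values here, no measured step changes a group on that aromatic carbon; the only measured step, a 1.5-fold higher number from compound 2 to compound 3 (0.19 log units; within the scatter), concerns a saturated ring carbon and lies within the scatter. A step beyond the scatter in this assay is therefore not expected. For compound 4 the expected value is 50000 nM, with a range of 20000 nM to 120000 nM, an estimated step of a 1.0-fold higher number from compound 3 to compound 4 (0.01 log units; within the scatter).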

Compound 4, half-maximal inhibitory concentration: > 60000 nM
Compound 4 gave a limit, no number; the forecaster's own chance of this, stated with the estimate: 40%; middle value at least 1.2-fold (0.07 log units) from the limit.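

In this assay compound 4 gives > 60000 nM, a limit of the assay and not a number. Methyl in place of fluoro on this aromatic carbon gives an at least 1.2-fold higher number from compound 3 to compound 4 (0.08 log units; that floor lies within the scatter), so only a floor can be read: this first change at the position brings no lower number, and the true size of the step stays unknown. Readings in this series now reach the assay ceiling from more than one compound: the limit of > 60000 nM in this assay, at which 2 of the 4 values shown sit.

The compounds shown leave open whether an amine or a carboxylic acid on this aromatic carbon would give a number clear of the limit. Also open, from the compounds shown here alone, is how methyl here reads with ethoxy in place of the phenyl on the saturated ring carbon.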